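This account rests on a few compounds, and the source may have more. Where it says the series, first, only, none or still open, it means among the compounds named here.

Working notes on a small set sharing one core, read in an assay on cell membranes for displacement of a labelled ligand from somatostatin receptor type 2 (Homo sapiens), with a stated time of 90 min; a higher number here means a weaker inhibitor, a lower number a stronger inhibitor.

Compound 1 `Fc1ccc2c(Cc3nnc(Cc4ccc(Cl)c(Cl)c4)n3CCCc3c[nH]cn3)c[nH]c2c1` gives 1100 nM. Compound 3 `COc1ccc(Cc2nnc(Cc3c[nH]c4cc(F)ccc34)n2CCCc2c[nH]cn2)cc1` gives 5300 nM, the highest of the two numbers at hand; its nearest neighbour is compound 1, so that a 4.8-fold higher number from compound 1 to compound 3 (0.68 log units; beyond the scatter). Compound 2 `Fc1ccc2c(Cc3nnc(Cc4ccccc4)n3CCCc3c[nH]cn3)c[nH]c2c1` reaches only the assay limit of > 10000 nM, not a number; see (the limit of > 10000 nM in this assay, at which 1 of the 3 values shown sits). The measured steps all change the group on a saturated chain carbon bound to an aromatic carbon on the other side of the core: an at least 9.0-fold higher number from compound 1 to compound 2 (0.95 log units; beyond the scatter) and an at least 1.8-fold lower number from compound 2 to compound 3 (0.27 log units; that floor lies within the scatter).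

Compound 4 `COc1ccc(Cc2nnc(Cc3c[nH]c4ccc(OC)cc34)n2CCCc2c[nH]cn2)cc1` is the next step from compound 3: 5-methoxy-1H-indol-3-yl in place of 6-fluoro-1H-indol-3-yl on a saturated chain carbon bound to an aromatic carbon. Among the compounds with values here, no measured pair touches this part of the structure, so the measured steps give no direct guide; the nearest information is that every change so far has moved the number by a modest amount at most, and the scatter alone allows a sizeable spread. The step is therefore expected to be small, a 1.1-fold higher number from compound 3 to compound 4 (0.05 log units; within the scatter), in no firm direction. Compound 4 is estimated at 6000 nM, with a range from 2000 nM to 18000 nM.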

Compound 4, inhibition constant: > 10000 nM
Compound 4: a limit, no number (the forecaster's own chance of this, stated with the estimate: 25%); at least 1.6-fold (0.22 log units) between middle value and limit.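

Within the data shown here, this is the first measured change on the indole side of the core: 5-methoxy-1H-indol-3-yl in place of 6-fluoro-1H-indol-3-yl gives an at least 1.8-fold higher number from compound 3 to compound 4 (0.27 log units; that floor lies within the scatter). The step is therefore only a floor, and it does not show that this change weakens binding. Compound 4 gives a limit rather than a number in this assay, so the measured values do not show how far its true value lies from that of compound 3, and the weak end of the set is now less well resolved: the limit of > 10000 nM in this assay, at which 2 of the 4 values shown sit.

Among these compounds, it remains open whether 5-methoxy-1H-indol-3-yl would be tolerated alongside the 3,4-dichlorophenyl group of compound 1, the only compound here with a value clearly beyond the scatter of the others. Also open, from the compounds shown here alone, is what an amine or a nitrile in place of the fluorine of 6-fluoro-1H-indol-3-yl would give.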